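The source may hold more compounds than are shown below. What is called first, only, known or untested is meant among the compounds shown, and "the series" means these compounds.

Two compounds share a cyclopropane core and differ in the group attached to it: compound 1 `COc1cc([C@H]2C[C@]2(CO)C(=O)Nc2ccccc2Cl)cc(OC)c1OC` carries a hydroxymethyl group, and compound 2 `CCOC(=O)[C@@]1(C(=O)Nc2ccccc2Cl)C[C@H]1c1cc(OC)c(OC)c(OC)c1` carries an ethyl ester. The difference between the two cores is not broken down here. In a functional assay on QGY cells (Homo sapiens) for cytotoxicity, read by MTT assay, with a stated time of 48 h (a lower number here means a stronger inhibitor, a higher number a weaker inhibitor), compound 1 gives 40700 nM, and in this assay compound 2 gives 34300 nM, a gap within the usual scatter.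

Compound 3 `COc1cc([C@H]2C[C@]2(CO)C(=O)Nc2ccccc2)cc(OC)c1OC` is compound 1 with hydrogen in place of chloro on an aromatic carbon. In this assay, going by these compounds, compound 3 reaches only a limit of the measurement, > 100000 nM, so its true value is unknown beyond that (the limit of > 100000 nM in this assay, at which 1 of the 3 values shown sits). Expressed as a step, that change gave an at least 2.4-fold higher number from compound 1 to compound 3 (0.39 log units; beyond the scatter).

Compound 4 `CCOC(=O)[C@@]1(C(=O)Nc2ccccc2)C[C@H]1c1cc(OC)c(OC)c(OC)c1` applies the same change to compound 2, namely (hydrogen in place of chloro on an aromatic carbon). Because the step from compound 1 to compound 3 was an at least 2.4-fold higher number from compound 1 to compound 3 (0.39 log units; beyond the scatter), a step of roughly similar size is expected here, so a 2.9-fold higher number from compound 2 to compound 4 (0.46 log units; beyond the scatter) is the estimated change. Compound 4 is therefore expected to give about 100000 nM in this assay, with a fair chance that only a limit is reported, as happened for compound 3.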

Compound 4, half-maximal inhibitory concentration: 48700 nM
Estimate against measurement, compound 4: 2.1-fold (0.31 log units) above; the range from low to high includes it.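

On the core that carries the ethyl ester, hydrogen in place of chloro gives a 1.4-fold higher number from compound 2 to compound 4 (0.15 log units; within the scatter) in this assay, so on this core the change has no clear effect. For the hydroxymethyl pair, compound 3 gives only a limit, > 100000 nM, and not a true number. The two pairs therefore show neither that the change keeps its size from one core to the other nor that its size truly differs between them, and one pair on each core is too little to support a rule for the series: the same change on two cores in this assay, an at least 2.4-fold higher number (0.39 log units; beyond the scatter) from compound 1 to compound 3 and a 1.4-fold higher number (0.15 log units; within the scatter) from compound 2 to compound 4; the limit leaves it open whether they differ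

The compounds shown leave open how other groups in the place of the chloro group, such as fluoro, methyl or methoxy, would read in this assay. They also leave open whether the step would look different on a core with a carboxylic acid or an amine in the place of the ethyl ester or hydroxymethyl group.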